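Adding a Second Methoxy Group on the Chalcone Ring

The source may report more compounds than this note shows. Statements on the series, on what has been measured and on what is new or still open speak of the compounds shown alone.

Compound 1 `C=C(Br)C(=O)Nc1ccc(C(=O)/C=C/c2ccc(OC)cc2)cc1` gives 310 nM in a functional assay on HeLa cells (Homo sapiens) for antiproliferative activity, with a stated time of 48 h; on this read-out lower numbers stand for stronger inhibition and higher numbers for weaker inhibition.
Compound 2 `C=C(Br)C(=O)Nc1ccc(C(=O)/C=C/c2cccc(OC)c2)cc1` gives 500 nM in this assay.
Compound 3 `C=C(Br)C(=O)Nc1ccc(C(=O)/C=C/c2ccc(OC)cc2OC)cc1` gives 1100 nM in this assay.

Compounds 1 and 2 share the same atoms joined differently: the difference is 3-methoxyphenyl in place of 4-methoxyphenyl on a double-bonded chain carbon bound to a double-bonded chain carbon. The step between them, a 1.6-fold higher number from compound 1 to compound 2 (0.21 log units; within the scatter), does not separate them. Compound 3 arises from compound 1 by methoxy in place of hydrogen on an aromatic carbon, and this step, a 3.5-fold higher number from compound 1 to compound 3 (0.55 log units; beyond the scatter), gives a modestly higher number.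

Compound 4 `C=C(Br)C(=O)Nc1ccc(C(=O)/C=C/c2cc(OC)cc(OC)c2)cc1` has not yet been measured in this assay. It arises from compound 2 by methoxy in place of hydrogen on an aromatic carbon. This is the same kind of change as from compound 1 to compound 3, although the surroundings differ: in compound 3 the entering methoxy sits ortho to a large group, while in compound 4 it sits meta to a large group; in both it sits meta to a methoxy group. Resting on the step of compound 3, a 3.5-fold higher number from compound 1 to compound 3 (0.55 log units; beyond the scatter), a step of similar size is expected here, a 2.8-fold higher number from compound 2 to compound 4 (0.45 log units; beyond the scatter), with a slightly wider spread given the changed surroundings. Compound 4 is therefore estimated at 1400 nM, between 600 nM and 3500 nM.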

Compound 4, half-maximal inhibitory concentration: 1700 nM
For compound 4 the middle estimate is 1.2-fold (0.08 log units) below the measured one, within the range that was stated.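

In this assay, methoxy in place of hydrogen on an aromatic carbon gives a 3.4-fold higher number from compound 2 to compound 4 (0.53 log units; beyond the scatter). Set beside the earlier case, the change carries over from one core to the other with a step of matching size: the same change on two cores in this assay, a 3.5-fold higher number (0.55 log units; beyond the scatter) from compound 1 to compound 3 and a 3.4-fold higher number (0.53 log units; beyond the scatter) from compound 2 to compound 4, 1.0-fold (0.02 log units) apart, within the scatter of two such steps

Within the data shown here, this agreement rests on only two pairs, each starting from a ring that already bears a methoxy group and each read in a single cell assay. It therefore does not show that the step would hold on a ring without methoxy, on other cores or in other assays, and it does not tell why the number rises.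

Methoxy is the only group entering in these steps, so it remains open whether a hydroxyl, an amine or a fluorine atom on the same aromatic carbon would move the number in the same direction. As far as these compounds go, it is also open whether a longer chain, such as ethoxy, would give a step of similar size.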